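Swapping 4-aminophenyl for methoxy in a cytotoxic quinone series

The source may hold more compounds than are shown below. What is called first, only, known or untested is meant among the compounds shown, and "the series" means these compounds.

For the measured compounds named here, in a functional assay on MIA PaCa-2 cells (Homo sapiens) for cytotoxicity, read by MTT assay, with a stated time of 72 h (on this read-out higher numbers stand for weaker inhibition and lower numbers for stronger inhibition), compound 2 (`Nc1ccc(-c2ccc(NC3=CC(=O)c4ncncc4C3=O)cc2)cc1`) gives 2500 nM and holds the lowest of the two numbers available so far. Compound 1 (`COc1cc(NC2=CC(=O)c3ncncc3C2=O)cc(OC)c1`) gives 7700 nM as the nearest number, higher by a gap beyond the usual scatter. Compound 3 (`O=C1C(Nc2cccc(B(O)O)c2)=CC(=O)c2ncncc21`) returns only a limit of the assay (> 10000 nM) and no number.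

Compound 4 (`COc1ccc(NC2=CC(=O)c3ncncc3C2=O)cc1`) has yet to be measured in this assay and departs from compound 2 in one place, with methoxy in place of 4-aminophenyl on an aromatic carbon, para to a large group (methoxy in place of 4-aminophenyl on an aromatic carbon). Going by the values given here, no two measured compounds differ in a single place, so no direct step is available to guide the expectation. Among the measured compounds, only compound 2 carries 4-aminophenyl. Compound 1, which carries methoxy, gives 7700 nM and serves as the closest comparison. The expected change a 2.4-fold higher number from compound 2 to compound 4 (0.38 log units; beyond the scatter) in this assay is therefore a move to a higher number, meaning weaker inhibition, of a size modestly beyond the scatter. Compound 4 is estimated at 6000 nM within an expected range of 2000 nM to 10000 nM in the same read-out.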

Compound 4, half-maximal inhibitory concentration: 1900 nM
Compound 4: the middle estimate sits 3.2-fold (0.50 log units) above what was measured; measured number below the stated range.
By their numbers in this assay, from the lowest: compounds 4 and 2 (each within the scatter of the next); then compound 1. At a limit, above all of these: compound 3.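

In this assay, putting methoxy in place of 4-aminophenyl on this aromatic carbon, para to a large group, gives a 1.3-fold lower number from compound 2 to compound 4 (0.12 log units; within the scatter). For the compounds shown here, this is the first comparison in the set between compounds that differ in one place, and it shows that the read-out does not separate the two groups at this position. The six-membered aromatic ring of carbon only and its hydrogen-bond donor can therefore leave this place, with methoxy entering instead, without a change that stands clear of the usual scatter, although this holds only for this single pair on the shared core. No measurement shown bears on why these two groups give values so alike.

The compounds shown leave open how much of this tolerance extends to other groups at the same aromatic carbon, such as a hydroxyl, a carboxylic acid, a simple amine or a longer chain like butoxy. They also leave open whether the same exchange would give a similarly small step on a different aromatic carbon of this series.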